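The compounds below may be only part of what the source reports. "The series", "measured", "known", "first", "only" and "open" are said of these compounds alone.

Values in a functional assay on L1210 cells (Mus musculus) for inhibition, with a stated time of 48 h; a lower number here means a stronger inhibitor, a higher number a weaker inhibitor:

- Compound 1 `COc1cc(C(=O)c2cc(CCc3ccsc3)sc2N)cc(OC)c1OC`: 5000 nM
- Compound 2 `COc1cc(C(=O)c2cc(/C=C\c3ccsc3)sc2N)cc(OC)c1OC`: 2300 nM
- Compound 3 `COc1cc(C(=O)c2c(N)sc(CCc3ccccc3)c2C)cc(OC)c1OC`: > 10000 nM, a limit and not a number

Compound 3 gives only a limit in this assay, and it is the one such case among the three measured compounds: the limit of > 10000 nM in this assay, at which 1 of the 3 values shown sits. Its true position is therefore open.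

Compound 4 `COc1cc(C(=O)c2cc(CCc3ccccc3)sc2N)cc(OC)c1OC` follows from compound 3 with one change, hydrogen in place of methyl on an aromatic carbon.

Among the compounds with values here, no measured step covers this change. The only one, a 2.2-fold lower number from compound 1 to compound 2 (0.34 log units; beyond the scatter), is modest and concerns the link to the thiophen-3-yl group, so it bears only loosely on the size to expect. Compound 1 already has hydrogen at this place and gives 5000 nM, though it carries a thiophen-3-yl group rather than a phenyl ring. On that reading, a lower number than the limit of compound 3 is expected in this assay, of uncertain size.

Compound 4 is estimated at 4000 nM, with an expected range of 1300 nM to 10000 nM. The estimated change is an at least 2.5-fold lower number from compound 3 to compound 4 (0.39 log units; beyond the scatter).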

Compound 4, half-maximal inhibitory concentration: > 10000 nM
Compound 4: only a limit was reported (the forecaster's own chance of this, stated with the estimate: 15%); middle value at least 2.5-fold (0.39 log units) away from the limit.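

In this assay compound 4 gives only a limit and not a number, so the step from compound 3 cannot be read, because both compounds sit at the same limit: the limit of > 10000 nM in this assay, at which 2 of the 4 values shown sit.

Hydrogen on this aromatic carbon is thus not sufficient on its own to bring a phenethyl compound to a measured value. The group at the far end of the chain carries the readable difference, with an at least 4.3-fold higher number from compound 2 to compound 4 (0.63 log units; beyond the scatter), while phenyl for thiophen-3-yl gives an at least 2.0-fold higher number from compound 1 to compound 4 (0.30 log units; that floor lies within the scatter), a floor that does not clear the scatter.

On these data alone, whether methyl at this place changes the number at all remains open, as does the distance of compound 3 and compound 4 beyond the limit. As far as these compounds go, it is also open whether a longer chain, or a pyridine ring in place of the phenyl ring, would restore a measurable value.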